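Fluoro in place of acetamido: the step to compound 4

The source may hold more compounds than are shown below. What is called first, only, known or untested is meant among the compounds shown, and "the series" means these compounds.

In an assay for inhibition of MAP kinase-interacting serine/threonine-protein kinase 1 (Homo sapiens), read by luminescence and ADP-Glo, with a stated time of 2 h (on this read-out higher numbers stand for weaker inhibition and lower numbers for stronger inhibition), compound 2 `CC(=O)Nc1cccc(Cn2cc(-c3ccc4c(N)n[nH]c4c3)ccc2=O)c1` gives 55 nM, the second highest of the three numbers. Compound 1 `Nc1n[nH]c2cc(-c3ccc(=O)n(Cc4cccc(Cl)c4)c3)ccc12` gives 11 nM, and compound 3 `NC(=O)c1ccccc1Cn1cc(-c2ccc3cn[nH]c3c2)ccc1=O`, on a different core, gives 878 nM. For the measured compounds named here, the one measured step bearing on the present change is a 5.0-fold higher number from compound 1 to compound 2 (0.70 log units; beyond the scatter), which came with acetamido in place of chloro on an aromatic carbon. Compound 4 `Nc1n[nH]c2cc(-c3ccc(=O)n(Cc4cccc(F)c4)c3)ccc12` undoes that kind of change: fluoro in place of acetamido on an aromatic carbon. Fluoro, like chloro, is a halogen, so the step to compound 4 is expected to run back toward compound 1, whose value is 11 nM, with a step of about the same size in the opposite direction. Compound 4 is therefore expected at 15 nM, within 6 nM to 40 nM, an expected step of a 3.7-fold lower number from compound 2 to compound 4 (0.56 log units; beyond the scatter).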

Compound 4, half-maximal inhibitory concentration: 19 nM
For compound 4 the middle estimate is 1.3-fold (0.10 log units) below the measured one; the range from low to high includes it.
By their numbers in this assay, from the lowest: compounds 1 and 4 (each within the scatter of the next); then compound 2; then compound 3.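

On this aromatic carbon, meta to a large group, fluoro gives a 2.9-fold lower number from compound 2 to compound 4 (0.46 log units; beyond the scatter) and is not separated from chloro, with a 1.7-fold higher number from compound 1 to compound 4 (0.24 log units; within the scatter) as the step between the two halogens on the shared core. Compound 2, with acetamido, thus stands apart from both halogen compounds, compound 1 and compound 4. Nothing at hand explains this difference.

Still open, as far as these compounds go, is whether a methoxy group, an amine or a carboxylic acid on this carbon would sit with the halogens or with compound 2. Bromo would test how far the halogen result extends.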